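The compounds below may be only part of what the source reports. "The series", "measured", "known", "first", "only" and "open" are said of these compounds alone.

Measured compounds in an ADME assay on Huh-7 cells (Homo sapiens) for cytotoxicity, read by MTT assay, with a stated time of 48 h; on this read-out lower numbers stand for higher toxicity in this test and higher numbers for lower toxicity in this test:
compound 1 `CN(C)CCCCOC(=O)Nc1ccc(Cn2nc(-c3cncnc3)c3ccccc3c2=O)cc1` gives 65300 nM
compound 2 `COc1ccc(-c2nn(Cc3ccc(NC(=O)OCCCCN(C)C)cc3)c(=O)c3ccccc23)cc1` gives 20300 nM
compound 3 `CN(C)CCCCOC(=O)Nc1ccc(Cn2nc(-c3cccc(F)c3)c3ccccc3c2=O)cc1` gives 37400 nM

Compound 3 sits second of the three numbers. Its step from compound 1 is a 1.7-fold lower number from compound 1 to compound 3 (0.24 log units; within the scatter) and its step from compound 2 is a 1.8-fold higher number from compound 2 to compound 3 (0.27 log units; within the scatter), so on the numbers shown it cannot be told apart from either. For the measured compounds named here, the only step beyond the scatter is a 3.2-fold lower number from compound 1 to compound 2 (0.51 log units; beyond the scatter), and it is modest.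

Compound 4 `CN(C)CCCCOC(=O)Nc1ccc(Cn2nc(-c3cccc(C(F)(F)F)c3)c3ccccc3c2=O)cc1` differs from compound 3 in one place: trifluoromethyl in place of fluoro on an aromatic carbon. Going by the values given here, no measured pair tests this exact exchange. Among the compounds with values here, the steps that bear on it are those that swap the aryl group on the same carbon of the shared core; of these, a 1.8-fold higher number from compound 2 to compound 3 (0.27 log units; within the scatter) and a 1.7-fold lower number from compound 1 to compound 3 (0.24 log units; within the scatter) stayed inside the scatter, and only the change to the methoxy-bearing ring moved the number. A single substituent swap on this ring has therefore produced, at most, a modest move in this assay, and the expectation for compound 4 is no step beyond the scatter, if anything a slightly lower number, which the estimate expresses as a 1.2-fold lower number from compound 3 to compound 4 (0.10 log units; within the scatter).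

Compound 4 is therefore expected to give about 30000 nM in this assay, with a range from 12000 nM to 75000 nM.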

Compound 4, half-maximal cytotoxic concentration: 11600 nM
Estimate against measurement, compound 4: 2.6-fold (0.41 log units) above, and the stated range ends above it.
By their numbers in this assay, from the lowest: compounds 4, 2, 3 and 1 (each within the scatter of the next, the first and the last beyond it).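

Within the series, the change from fluoro to trifluoromethyl on the aromatic carbon meta to a large group gives a 3.2-fold lower number from compound 3 to compound 4 (0.51 log units; beyond the scatter) in this assay, showing that a substituent exchange at this one place on the ring can move the number beyond the scatter, by the same printed size as a 3.2-fold lower number from compound 1 to compound 2 (0.51 log units; beyond the scatter), which needed a change of the whole aryl group. For the compounds shown here, the 3-(trifluoromethyl)phenyl group also widens the span of the series, with a 5.6-fold lower number from compound 1 to compound 4 (0.75 log units; beyond the scatter) as the largest step so far, while a 1.8-fold lower number from compound 2 to compound 4 (0.24 log units; within the scatter) leaves it indistinguishable from the 4-methoxyphenyl group in this test. Nothing at hand bears on the reason for the step from fluoro to trifluoromethyl.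

As far as these compounds go, it remains open whether the drop follows the size of the substituent or is particular to trifluoromethyl, a question that a methyl, a chloro, a nitrile or an amine on the same carbon would address. Also open, from the compounds shown here alone, is whether the same exchange would hold on a compound with a longer chain in place of the dimethylaminobutyl carbamate side of the shared core.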